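The compounds below may be only part of what the source reports. "The series", "measured", "known", "first", "only" and "open" are said of these compounds alone.

Measured so far:
compound 1 `COc1ccc(S(=O)(=O)N2CCc3cc(Br)cc(NC(=O)c4ccncc4)c32)cc1` — 91 nM
compound 2 `COc1ccc(S(=O)(=O)N2CCc3cccc(NCc4ccccc4)c32)cc1` — > 10000 nM

In a functional assay on KB cells (Homo sapiens) for cytotoxicity (a higher number here means a weaker inhibitor, a lower number a stronger inhibitor), compound 1 gives 91 nM. Compound 2 gives only a limit in this assay, > 10000 nM, so its standing is known only as a boundary and not as a number; it sits at the limit of > 10000 nM in this assay, at which 1 of the 2 values shown sits. Compound 3 `COc1ccc(S(=O)(=O)N2CCc3cccc(NC(C)=O)c32)cc1` differs from compound 2 in one place: acetyl in place of benzyl on a nitrogen on an aromatic ring. Put another way, the benzylamino group becomes an acetamido group, and the shared core of compound 2 is otherwise kept.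

Among the compounds with values here, because compound 2 sits at the limit of > 10000 nM in this assay, at which 1 of the 2 values shown sits, no measured step leads from it, and the size of the change to compound 3 cannot be read from a neighbouring pair. Compound 1, which also carries an amide on that nitrogen, gives 91 nM, but it differs from compound 3 in more than one place, so only its value is noted here. The step from compound 2 to compound 3 is expected to be an at least 3.3-fold lower number from compound 2 to compound 3 (0.52 log units; beyond the scatter), that is, towards a stronger inhibitor, though with wide uncertainty. Compound 3 is therefore estimated at 3000 nM in this assay, within a range from 400 nM to 20000 nM.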

Compound 3, half-maximal inhibitory concentration: 89 nM
Compound 3: middle estimate off by 34-fold (1.53 log units), on the high side; the measured number lies below the stated range.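

In this assay, replacing benzylamino with acetamido on the otherwise unchanged core gives an at least 110-fold lower number from compound 2 to compound 3 (2.05 log units; beyond the scatter). This shows that the group on this nitrogen can decide whether the pair's cytotoxicity is measurable at all, and that the smaller acetyl, with its carbonyl, is compatible with a strong inhibitor on this core. The step gives only a minimum size and not an exact one because compound 2 stands at a limit: the limit of > 10000 nM in this assay, at which 1 of the 3 values shown sits.

The pair does not separate the loss of the benzyl ring from the arrival of the carbonyl, as both change in this single step. It also leaves open whether the free amine, a longer acyl chain or a benzoyl group on this nitrogen would match the acetyl.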